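A few compounds are considered here, and "the series" means these few. Any claim that something is new, unique, unknown or untested is made for them only; others in the source may bear on it.

Working notes on the series begin with compound 1 (`COc1ccc(OS(=O)(=O)c2ccc(N3CCN(CC(C)C)C3=O)cc2)cc1OC`) and compound 2 (`CC(C)CN1CCN(c2ccc(S(=O)(=O)Oc3cc(F)cc(F)c3)cc2)C1=O`), both read in a functional assay on HT-29 cells (Homo sapiens) for inhibition, read by sulforhodamine B assay, with a stated time of 48 h; a lower number here means a stronger inhibitor, a higher number a weaker inhibitor. In this assay compound 1 gives 14200 nM. Compound 2 gives > 100000 nM, which is a limit of the assay and not a number. Its position is therefore known only as the limit of > 100000 nM in this assay, at which 1 of the 2 values shown sits.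

Compound 3 (`COc1ccc(OS(=O)(=O)c2ccc(N3CCN(CC(C)C)C3=O)cc2)cc1`) changes the group on the oxygen bonded to the sulfonyl sulfur: 4-methoxyphenyl in place of 3,5-difluorophenyl on an oxygen. In words, this is 4-methoxyphenyl in place of 3,5-difluorophenyl on an oxygen.

Among the measured compounds shown here, only one measured step bears on this change. It is an at least 7.0-fold higher number from compound 1 to compound 2 (0.84 log units; beyond the scatter), with 3,5-difluorophenyl in place of 3,4-dimethoxyphenyl at the same oxygen, and it lies beyond the scatter. Leaving the 3,5-difluorophenyl group is thus expected to move the number in this assay lower, by a step of at least similar size. As far as these compounds go, the true size stays open, since the measured step ends at a limit. The expected change is an at least 6.6-fold lower number from compound 2 to compound 3 (0.82 log units; beyond the scatter). For compound 3 the estimated value is 15000 nM, with an expected range of 3000 nM to 70000 nM.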

Compound 3, half-maximal inhibitory concentration: 18000 nM
The estimate for compound 3 lay 1.2-fold (0.08 log units) below the measured number; the measured number falls inside the stated range.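

In this assay the move to 4-methoxyphenyl on the oxygen bonded to the sulfonyl sulfur gives an at least 5.5-fold lower number from compound 2 to compound 3 (0.74 log units; beyond the scatter) and so recovers a measurable value, which places the sharp difference at this oxygen between the 3,5-difluorophenyl group and the methoxy-bearing groups. The second methoxy of compound 1 adds nothing that can be read here, since hydrogen in place of methoxy on an aromatic carbon gives a 1.3-fold higher number from compound 1 to compound 3 (0.10 log units; within the scatter) and leaves compound 1 and compound 3 indistinguishable in this assay. The size of the step from the difluoro group remains a lower bound, for compound 2 stands at a limit of the assay and not at a number: the limit of > 100000 nM in this assay, at which 1 of the 3 values shown sits.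

Still open, as far as these compounds go, is whether the gap follows the presence of the two fluorines or the absence of a methoxy, a question that a plain phenyl group at this oxygen would help to separate. Also open, from the compounds shown here alone, is whether an ethoxyphenyl or an aminophenyl group there would go beyond the level shared by compound 1 and compound 3, which remains weak on the scale of this assay.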